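Mirror-image pair in a sigma-1 binding series

A few compounds are considered here, and "the series" means these few. Any claim that something is new, unique, unknown or untested is made for them only; others in the source may bear on it.

Measured compounds:
compound 1, `CN(C)CC[C@H]1CCC[C@@H](c2ccccc2)C1`, 10 nM
compound 2, `c1ccc(CNCC[C@H]2CCC[C@H](c3ccccc3)C2)cc1`, 1.4 nM
compound 3, `c1ccc([C@H]2CCC[C@@H](CCN3CCN(c4ccccc4)CC3)C2)cc1`, 16 nM

All three were tested in an assay on membranes from brain for displacement of a labelled ligand from Sigma non-opioid intracellular receptor 1 (Cavia porcellus), read by scintillation counting, with a stated time of 120 min; a lower number here means a stronger inhibitor, a higher number a weaker inhibitor. Among the three numbers, compound 1 with 10 nM stands second highest. Its nearest neighbour is compound 3, whose value of 16 nM lies within the scatter of that of compound 1, so no order can be read between those two. The furthest is compound 2, whose value of 1.4 nM lies beyond the scatter and is the lowest of the three.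

Compound 4, `CN(C)CC[C@@H]1CCC[C@H](c2ccccc2)C1`, has not yet been measured in this assay. Compared with compound 1, (the two compounds have the same atoms and bonds and differ only in configuration as drawn: 2 of 2 stereo elements differ (all stereocentres are inverted: mirror images); a stereocentre at a saturated ring carbon is drawn S in compound 1 and R in compound 4; a stereocentre at a saturated ring carbon is drawn R in compound 1 and S in compound 4). Going by the values given here, since no pair of mirror images has been measured here, nothing in the data shows how large a step such an inversion brings in this assay. Enantiomers can differ, and the expected step from compound 1 to compound 4 is a 2.5-fold higher number from compound 1 to compound 4 (0.40 log units; beyond the scatter), a modest weakening that may or may not exceed the scatter. Compound 4 is therefore estimated at 25 nM, with a range from 6 nM to 100 nM.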

Compound 4, inhibition constant: 14 nM
Compound 4: the middle estimate sits 1.8-fold (0.25 log units) above what was measured, and the stated range covers the measured number.
By their numbers in this assay, from the lowest: compound 2; then compounds 1, 4 and 3 (each within the scatter of the next).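

Going by these compounds alone, compound 1 and compound 4 form the first mirror-image pair, and in this assay inverting both stereocentres gives a 1.4-fold higher number from compound 1 to compound 4 (0.15 log units; within the scatter). With the dimethylamino group on the chain, this assay therefore does not separate the two enantiomers, and no preference for either configuration at these two ring carbons can be read from the pair. The comparison is a clean test of configuration alone, since nothing else varies between the two compounds: the fact that compounds 1 and 4 differ only in the configuration as drawn.

Whether the same holds with other amines is open, as the mirror images of compound 2 and compound 3 are not among the compounds shown, and neither is a dimethylamino compound with only one of the two stereocentres inverted. From the compounds shown here alone, how a diethylamino group or a longer chain between the core and the amine would behave under the same inversion also remains unknown, so the result applies only to this one pair and cannot be extended to the series as a whole.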